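Replacing Dimethylamino with Pyrrolidinyl on the Chain

A few compounds are considered here, and "the series" means these few. Any claim that something is new, unique, unknown or untested is made for them only; others in the source may bear on it.

Three compounds have been measured in a functional assay on A549 cells (Homo sapiens) for cytotoxicity, read by MTT assay, with a stated time of 72 h; a lower number here means a stronger inhibitor, a higher number a weaker inhibitor:

Compound 1 `COc1c(OCCCCN2CCN(C)CC2)cc(O)c2c(=O)cc(-c3ccc(C)cc3)oc12` gives 3810 nM.
Compound 2 `COc1c(OCCCCN2CCN(C)CC2)cc(O)c2c(=O)cc(-c3ccc([N+](=O)[O-])cc3)oc12` gives 3210 nM.
Compound 3 `CN(C)CCCOc1c(OCc2ccccc2)cc(O)c2c(=O)cc(-c3ccccc3)oc12` gives 2910 nM.

Compound 3 carries the lowest of the three numbers, yet its neighbours are close: the gap to compound 2 and the gap to compound 1 both lie within the scatter of this assay, so no ranking of the three can be claimed. Within the data shown here, the one measured step that differs in a single place, a 1.2-fold lower number from compound 1 to compound 2 (0.07 log units; within the scatter), concerns the substituent on the aryl ring at the far end of the molecule and is itself within the scatter.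

Compound 4 `O=c1cc(-c2ccccc2)oc2c(OCCCN3CCCC3)c(OCc3ccccc3)cc(O)c12` differs from compound 3 by pyrrolidin-1-yl in place of dimethylamino on a saturated chain carbon, three bonds along the chain from an oxygen on an aromatic ring. Among the measured compounds shown here, no measured pair isolates this change: compounds 1 and 2 carry a different amine on a longer chain and differ from compound 3 in more than one place, so their values can only be read as a loose backdrop, one in which three different amine-bearing chains all give numbers within the scatter of one another. On that basis the expected step of a 1.0-fold lower number from compound 3 to compound 4 (0.02 log units; within the scatter) is none beyond the scatter. Compound 4 is therefore estimated at 2800 nM, with a range from 1300 nM to 6000 nM.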

Compound 4, half-maximal inhibitory concentration: 4720 nM
Beside the measured number, compound 4's estimate is 1.7-fold (0.23 log units) below it, and the stated range covers the measured number.
By their numbers in this assay, from the lowest: compounds 3, 2, 1 and 4 (each within the scatter of the next).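

Read directly for the first time, the change at the end of this chain gives in this assay a 1.6-fold higher number from compound 3 to compound 4 (0.21 log units; within the scatter). Compounds 1 and 2 could offer only a loose backdrop for this position, whereas this pair, alike except for the amine, shows that a five-membered non-aromatic ring can take the place of dimethylamino on the 3-carbon chain with no change that can be told from the scatter. Nothing on hand accounts for the value of compound 4, and the step is too small to need or support an explanation.

The compounds shown leave open whether a morpholine or a piperidine in place of pyrrolidin-1-yl, or a 2-(pyrrolidin-1-yl)ethyl chain in place of the 3-(pyrrolidin-1-yl)propyl chain, would move the number beyond the scatter. Going by these compounds, it also remains open whether the same exchange of amines would give a similar step with a methyl or nitro group on the far aryl ring, or with a methoxy group in place of the benzyloxy group.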